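Swapping chloro for cyano near a solubility limit

The source may hold more compounds than are shown below. What is called first, only, known or untested is meant among the compounds shown, and "the series" means these compounds.

The compounds here share one core, and the read-out is a physicochemical assay for solubility, using the shake flask method, measured as kinetic solubility, with a stated time of 2 h, at pH 7.4; on this read-out lower numbers stand for lower solubility and higher numbers for higher solubility. Compound 1 is `CN(c1ccccc1)c1cc(C(=O)Nc2ccccc2)ncn1`. In this assay compound 1 gives < 5000 nM, which is a limit and not a number. Among the measured compounds shown here, compound 2, `CCN(Cc1ccc(Cl)cc1)c1cc(C(=O)Nc2ccccc2)ncn1`, gives 5000 nM, the only true number so far. Compound 3, `CN(Cc1ccc(Cl)cc1)c1cc(C(=O)Nc2ccccc2)ncn1`, gives < 5000 nM, and this too is a limit and not a number.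

Compound 4, `CN(Cc1ccc(C#N)cc1)c1cc(C(=O)Nc2ccccc2)ncn1`, differs from compound 3 in one place: cyano in place of chloro on an aromatic carbon. Put simply, a cyano group replaces the chloro group, para to a large group.

For the measured compounds named here, two measured steps touch compound 3: a step that the two limits leave unreadable from compound 1 to compound 3 and a number no higher from compound 2 to compound 3 (the limit leaves the size open). Neither has a readable size, and neither changes the chloro group, so they offer no size to carry over. Another limit for compound 4 would be no surprise because of the limit of < 5000 nM in this assay, at which 2 of the 3 values shown sit. The estimate for the step is a step that the limit leaves unreadable from compound 3 to compound 4, which means no expected change beyond the usual scatter, in either direction. For compound 4 the estimated value is 4000 nM, with an expected range from 1500 nM to 10000 nM.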

Compound 4, solubility: < 5000 nM
Compound 4: no number, only a limit; the forecaster's own chance of this, stated with the estimate: 60%; the middle value does not contradict the limit.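

In this assay compound 4 gives < 5000 nM, which is a limit and not a number. Compound 3 also has only a limit, so no step can be read between compound 3 and compound 4, and the reason is this: the limit of < 5000 nM in this assay, at which 3 of the 4 values shown sit.

On these data alone, whether cyano in place of chloro changes the read-out at all, and by how much, stays open.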